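The source may hold more compounds than are shown below. What is called first, only, known or untested is meant among the compounds shown, and "the series" means these compounds.

In a functional assay on the whole organism for positive allosteric modulation, with Mus musculus as the target (a higher number here means that more compound is needed for the effect, a lower number that less compound is needed), compound 1 (`CCC(=O)N(c1cccc(OC)c1)C1CCCC1N(C)C`), with methoxy on an aromatic carbon, gives 4 mg/kg and compound 2 (`CCC(=O)N(c1cccc(Br)c1)C1CCCC1N(C)C`), with bromo on that carbon, gives 2 mg/kg on the same scale. These two numbers lie within the scatter of each other, so compound 2 cannot be ranked against compound 1 on the present data. Compound 3 (`CCC(=O)N(c1cccc(C(F)(F)F)c1)C1CCCC1N(C)C`) keeps the shared core and changes that same carbon again, with trifluoromethyl in place of bromo on an aromatic carbon as the only difference. Within the data shown here, no measured pair shows this exact swap, so the one available guide is the earlier exchange at that position. Swapping the group there has so far given only a 2.0-fold lower number from compound 1 to compound 2 (0.30 log units; within the scatter) and so no shift beyond the scatter is expected in this assay in either direction. The expected change is a 1.5-fold higher number from compound 2 to compound 3 (0.18 log units; within the scatter) and it is an estimate resting on a single step, which is thin evidence. Compound 3 is estimated at 3 mg/kg with 1 mg/kg to 8 mg/kg as its expected range.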

Compound 3, dose for half-maximal effect: 0.9 mg/kg
Estimate against measurement, compound 3: 3.3-fold (0.52 log units) above; measured number outside the range, below it.
By their numbers in this assay, from the lowest: compound 3; then compounds 2 and 1 (each within the scatter of the next).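

In this assay, trifluoromethyl in place of bromo on this aromatic carbon gives a 2.2-fold lower number from compound 2 to compound 3 (0.35 log units; beyond the scatter) and trifluoromethyl in place of methoxy gives a 4.4-fold lower number from compound 1 to compound 3 (0.65 log units; beyond the scatter). Among these compounds, the earlier exchange of methoxy for bromo stayed within the scatter, so only now is it clear that a change at this one carbon can move the required dose by more than the usual variation between repeated measurements, and compound 3 is the only compound of the three separated from both others by steps beyond the scatter. The data give the size of this shift but offer no measurement that accounts for it.

On these data alone, it remains open whether other groups on this carbon, such as a nitrile, an amine or a carboxylic acid, would give a number lower still or would lose the shift seen with trifluoromethyl. Also open, as far as these compounds go, is whether the step to trifluoromethyl keeps its size when another part of the shared core is changed, for instance when a longer chain replaces an existing one.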